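Sulfonyl aryl enlargement in a tetradecylamide threonine series

This account rests on a few compounds, and the source may have more. Where it says the series, first, only, none or still open, it means among the compounds named here.

Measured compounds:
compound 1, `CCCCCCCCCCCCCCNC(=O)[C@@H](NC(=O)c1cc2ccccc2[nH]1)[C@@H](C)O`, 12300 nM
compound 2, `CCCCCCCCCCCCCCNC(=O)[C@@H](NS(=O)(=O)c1ccc(C)cc1)[C@@H](C)O`, 12000 nM

In a functional assay on A-431 cells (Homo sapiens) for cytotoxicity, read by MTT assay, with a stated time of 48 h (a higher number here means a weaker inhibitor, a lower number a stronger inhibitor), compound 2 and compound 1 give numbers that cannot be told apart, the step being a 1.0-fold lower number from compound 1 to compound 2 (0.01 log units; within the scatter). Compound 3, `CCCCCCCCCCCCCCNC(=O)[C@@H](NS(=O)(=O)c1ccc2ccccc2c1)[C@@H](C)O`, differs from compound 2 by naphthalen-2-yl in place of 4-methylphenyl on a sulfonyl sulfur. For the measured compounds named here, no measured step touches this aryl change on the sulfonyl sulfur; the only step known, a 1.0-fold lower number from compound 1 to compound 2 (0.01 log units; within the scatter), exchanged the entire group on the amine nitrogen without effect beyond the scatter, so no step beyond the scatter is expected for compound 3, a 1.2-fold lower number from compound 2 to compound 3 (0.08 log units; within the scatter). Compound 3 is estimated at 10000 nM, within 4000 nM to 25000 nM.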

Compound 3, half-maximal inhibitory concentration: 19600 nM
Beside the measured number, compound 3's estimate is 2.0-fold (0.29 log units) below it; low and high end bracket the measured number.
By their numbers in this assay, from the lowest: compounds 2, 1 and 3 (each within the scatter of the next).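

In this assay, naphthalen-2-yl in place of 4-methylphenyl on the sulfonyl sulfur gives a 1.6-fold higher number from compound 2 to compound 3 (0.21 log units; within the scatter) and so adds a second six-membered aromatic ring of carbon only with no step beyond the scatter. Earlier, only the entire group on the amine nitrogen had been exchanged; this step reads the aryl group alone. No available evidence bears on this result.
Open, from the compounds shown here alone, is whether an amine or a carboxylic acid on the aryl group would give a step beyond the scatter. Also open, going by these compounds, is what a shorter chain in place of the tetradecyl chain would give.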